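The source may hold more compounds than are shown below. What is called first, only, known or untested is meant among the compounds shown, and "the series" means these compounds.

Compound 1 `Nc1nc(-c2nn(Cc3ccccc3F)c3ncccc23)nc(N)c1NC(=O)OC1CCC1` gives 0.2 uM in an assay on cells for activation of Guanylate cyclase soluble subunit alpha-1 (Rattus norvegicus), read by cGMP accumulation and immunoassay, with a stated time of 10 min; on this read-out higher numbers stand for an effect only at larger amounts of compound and lower numbers for an effect already at smaller amounts.
Compound 2 `Nc1nc(-c2nn(Cc3ccccc3F)c3ncccc23)nc(N)c1NC(=O)OC1COC1` gives 2.3 uM in this assay.
Compound 3 `Nc1nc(-c2nn(Cc3ccccc3F)c3ncccc23)nc(N)c1NC(=O)OCC(F)(F)F` gives 0.2 uM in this assay.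

Compound 3 stands level with compound 1 at the digits shown, the two together giving the lowest numbers, while compound 2 is furthest away: a 12-fold lower number from compound 2 to compound 3 (1.06 log units; beyond the scatter). Compound 4 `Nc1nc(-c2nn(Cc3ccccc3F)c3ncccc23)nc(N)c1N1C[C@@H](C(F)(F)F)OC1=O` differs from compound 3 by 2-oxo-5-(trifluoromethyl)-1,3-oxazolidin-3-yl in place of ((2,2,2-trifluoroethoxy)carbonyl)amino on an aromatic carbon. Among the measured compounds shown here, none of the measured steps makes this kind of change; all three only swap the group on the oxygen, and the one that brought in a small ring rose: a 12-fold higher number from compound 1 to compound 2 (1.06 log units; beyond the scatter). The trifluoromethyl stays, so compound 4 is expected close to compound 3, with a small rise or no step beyond the scatter: a 2.5-fold higher number from compound 3 to compound 4 (0.40 log units; beyond the scatter). Compound 4 is estimated at 0.5 uM, range 0.1 uM to 3 uM.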

Compound 4, minimum effective concentration: 0.03 uM
Compound 4: middle estimate off by 17-fold (1.22 log units), on the high side; measured number outside the range, below it.
By their numbers in this assay, from the lowest: compound 4; then compounds 1 and 3 (each within the scatter of the next); then compound 2.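

Until now only the group on the oxygen had changed, and no number went lower than those of compounds 1 and 3. Putting the ring 2-oxo-5-(trifluoromethyl)-1,3-oxazolidin-3-yl on this aromatic carbon, in place of the open chain with its hydrogen-bond donor, goes lower in this assay: a 6.7-fold lower number from compound 3 to compound 4 (0.82 log units; beyond the scatter), a 6.7-fold lower number from compound 1 to compound 4 (0.82 log units; beyond the scatter) and a 77-fold lower number from compound 2 to compound 4 (1.88 log units; beyond the scatter). Nothing given here explains the drop.

Still open, from the compounds shown here alone, is how the mirror-image form of the ring would read, or the same ring with methyl in place of trifluoromethyl. Also open, going by these compounds, is whether the ring or the lost amide hydrogen carries the step, which an open chain with a methyl on that nitrogen could separate.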